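The compounds below may be only part of what the source reports. "The series", "measured", "known", "first", "only" and "open" are said of these compounds alone.

In a functional assay on HT-29 cells (Homo sapiens) for cytotoxicity, read by MTT assay, with a stated time of 6 days (a lower number here means a stronger inhibitor, a higher number a weaker inhibitor), three related compounds have been measured so far. Compound 1 `COc1ccc2c(c1)OCC(=O)N2Cc1cn(Cc2ccccc2)nn1` gives 9300 nM. Compound 2 `CCCC1Oc2ccccc2N(Cc2cn(Cc3ccccc3)nn2)C1=O` gives > 100000 nM, which is a limit of the assay and not a number. Compound 3 `CC(C)(C)c1ccc(Cn2cc(CN3C(=O)COc4ccccc43)nn2)cc1` gives 25100 nM, the higher of the two actual numbers, and its gap to compound 1 lies beyond the usual scatter. Compound 4 `O=C1COc2ccccc2N1Cc1cn(Cc2ccc([N+](=O)[O-])cc2)nn1` is still unmeasured; it has nitro in place of tert-butyl on an aromatic carbon, para to a large group (nitro in place of tert-butyl on an aromatic carbon). Among the measured compounds shown here, no measured pair isolates this change, so the step expected a 1.4-fold lower number from compound 3 to compound 4 (0.14 log units; within the scatter) in this assay is small, within the scatter, towards a lower number. For compound 4 the estimated value is 18000 nM, with an expected range from 6000 nM to 60000 nM.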

Compound 4, half-maximal inhibitory concentration: 15600 nM
Compound 4: the middle estimate sits 1.2-fold (0.06 log units) above what was measured, within the range that was stated.
By their numbers in this assay, from the lowest: compounds 1, 4 and 3 (each within the scatter of the next, the first and the last beyond it). At a limit, above all of these: compound 2.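

Among the compounds shown here, putting nitro in place of tert-butyl on an aromatic carbon, para to a large group, gives a 1.6-fold lower number from compound 3 to compound 4 (0.21 log units; within the scatter) in this assay, the first measured pair that isolates a change at this position. These two groups differ in their atoms, yet this assay does not separate them here. Nothing measured here gives a cause for this step.

Going by these compounds, whether an amine, a carboxylic acid or a longer chain at this carbon would move the number beyond the scatter remains open. So does whether the hydrogen-free parent position would read the same.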